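The source may report more compounds than this note shows. Statements on the series, on what has been measured and on what is new or still open speak of the compounds shown alone.

Measured so far in a functional assay on HT-29 cells (Homo sapiens) for antiproliferative activity, with a stated time of 48 h; on this read-out lower numbers stand for stronger inhibition and higher numbers for weaker inhibition:
compound 1, `CCCCC(O)c1cccc(NC(=O)NC(=O)CC)c1`: > 100000 nM
compound 2, `CCCCC(O)c1cccc(NC(=O)CCCl)c1`: > 100000 nM

Both values shown for this assay are limits of the assay and not numbers. Compound 1 sits at the limit of > 100000 nM in this assay. Compound 2 likewise sits at the limit of > 100000 nM in this assay, so its position on the scale is known only as this bound. Among the measured compounds shown here, the one step between measured compounds, from compound 1 to compound 2, is therefore a step that the two limits leave unreadable from compound 1 to compound 2; both ends sit at the limit of > 100000 nM in this assay, at which 2 of the 2 values shown sit, and the step carries no readable size or direction.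

The next compound, compound 3 `C=CC(=O)Nc1cccc(C(O)CCCC)c1`, differs from compound 2 by vinyl in place of 2-chloroethyl on a carbonyl carbon. For the measured compounds named here, no measured step bears on this change: the only step is unreadable, and nothing indicates whether the common core tolerates any change at all. The expectation for compound 3 therefore rests on the two limits alone, and the step from compound 2 to compound 3 is estimated as an at least 1.2-fold lower number from compound 2 to compound 3 (0.09 log units; that floor lies within the scatter), most probably no movement beyond the scatter. Compound 3 is accordingly estimated at 80000 nM in this assay, with a range from 15000 nM to 300000 nM, and a further limit rather than a number remains the likelier outcome.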

Compound 3, half-maximal inhibitory concentration: > 100000 nM
Compound 3: a limit, no number (the forecaster's own chance of this, stated with the estimate: 65%); middle value at least 1.2-fold (0.09 log units) from the limit.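

In this assay compound 3 gives > 100000 nM, a limit and not a number. No step from compound 1 or compound 2 to compound 3 can be read, and the series stays at a single bound: the limit of > 100000 nM in this assay, at which 3 of the 3 values shown sit.

The compounds shown leave open whether any change on the shared core gives a readable number in this assay.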